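This account rests on a few compounds, and the source may have more. Where it says the series, first, only, none or still open, it means among the compounds named here.

Two close relatives of the same core open the set. Compound 1 `Clc1ccc(C2CC(c3ccccc3)=NN2c2ccc(-c3ccccc3)nn2)cc1` carries a chlorophenyl group on one side of the shared core and a plain phenyl group on the other. In an ADME assay on HEK293 cells (Homo sapiens) for cytotoxicity, read by MTT assay, with a stated time of 24 h (a lower number here means a stronger inhibitor, a higher number a weaker inhibitor), compound 1 reaches only the limit of the measurement, > 300000 nM, and no number. Compound 2 `Clc1ccc(C2=NN(c3ccc(-c4ccccc4)nn3)C(c3ccccc3)C2)cc1` turns the same two groups around on the core. In this assay compound 2 likewise stops at the limit, > 300000 nM, which is not a number. Compound 2 therefore stands where everything measured so far stands: at the limit of > 300000 nM in this assay, at which 2 of the 2 values shown sit, with nothing to separate it from compound 1.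

Compound 3 `Clc1ccc(C2=NN(c3ccc(-c4ccccc4)nn3)C(c3ccc(Cl)cc3)C2)cc1` follows from compound 2 by a single change, (chloro in place of hydrogen on an aromatic carbon), that is, chloro in place of hydrogen on an aromatic carbon of a six-membered aromatic ring of carbon only, para to a large group. For the measured compounds named here, no measured pair shows how such a step moves this assay. With both measured compounds resting at the limit, the step from compound 2 to compound 3 is expected to be a step that the limit leaves unreadable from compound 2 to compound 3, nothing beyond the usual scatter. Compound 3 is thus expected to give about 400000 nM in this assay, estimated between 150000 nM and 1000000 nM, most probably again reported only as a limit.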

Compound 3, half-maximal inhibitory concentration: > 300000 nM
Compound 3: only a limit was reported; the forecaster's own chance of this, stated with the estimate: 85%; the middle value lies beyond the limit too.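

In this assay compound 3 gives only a limit, > 300000 nM, and no number. No step from compound 1 or compound 2 to compound 3 can be read, because all three compounds rest at the same point: the limit of > 300000 nM in this assay, at which 3 of the 3 values shown sit.

The compounds shown leave open whether chloro in place of hydrogen on an aromatic carbon changes the result in this assay at all.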